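The compounds below may be only part of what the source reports. "The series", "measured", "known", "first", "only" and "open" are said of these compounds alone.

Measured so far in a functional assay on A549 cells (Homo sapiens) for cytotoxicity, with a stated time of 48 h; on this read-out higher numbers stand for weaker inhibition and lower numbers for stronger inhibition:
- compound 1 `CCOc1ccc2oc(/C=C/[S+](C)[O-])cc(=O)c2c1` gives 1500 nM
- compound 2 `CCCCCOc1ccc2oc(/C=C/[S+](C)[O-])cc(=O)c2c1` gives 1600 nM
- compound 3 `CCCC(=O)Oc1ccc2oc(/C=C/[S+](C)[O-])cc(=O)c2c1` gives 2200 nM

Compound 3 stands within the scatter of both other compounds, with steps of a 1.5-fold higher number from compound 1 to compound 3 (0.17 log units; within the scatter) and a 1.4-fold higher number from compound 2 to compound 3 (0.14 log units; within the scatter) leading to it. Compound 4 `CC(C)CC(=O)Oc1ccc2oc(/C=C/[S+](C)[O-])cc(=O)c2c1` differs from compound 3 by methyl in place of hydrogen on a saturated chain carbon bound to two saturated chain carbons, which turns propylcarbonyl into isobutylcarbonyl. The closest measured chain change, a 1.1-fold higher number from compound 1 to compound 2 (0.03 log units; within the scatter), also stays within the scatter. No step beyond the scatter is therefore expected in this assay. The expected step is a 1.1-fold lower number from compound 3 to compound 4 (0.04 log units; within the scatter). For compound 4 the estimated value is 2000 nM, with an expected range from 1100 nM to 3600 nM.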

Compound 4, half-maximal inhibitory concentration: 2300 nM
For compound 4 the middle estimate is 1.2-fold (0.06 log units) below the measured one, within the range that was stated.
By their numbers in this assay, from the lowest: compounds 1, 2, 3 and 4 (each within the scatter of the next).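

In this assay, methyl in place of hydrogen on a saturated chain carbon bound to two saturated chain carbons, turning propylcarbonyl into isobutylcarbonyl, gives no step beyond the scatter (a 1.0-fold higher number from compound 3 to compound 4 (0.02 log units; within the scatter)). Isobutylcarbonyl on this oxygen also stays within the scatter of the pentyl and ethyl chains (a 1.4-fold higher number from compound 2 to compound 4 (0.16 log units; within the scatter); a 1.5-fold higher number from compound 1 to compound 4 (0.19 log units; within the scatter)), so this branch adds no separation among compounds 1 to 4. No measured evidence bears on why these numbers stay so close.

Open, as far as these compounds go, is whether an amine or a carboxylic acid at the end of this chain, or a chain longer than pentyl, would give a step beyond the scatter.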